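From Compound 2 to Compound 3: A Side Chain Exchanged

The compounds below may be only part of what the source reports. "The series", "measured", "known", "first", "only" and "open" are said of these compounds alone.

In an ADME assay for permeability, using PAMPA, with a stated time of 4 h, at pH 5.5 (on this read-out lower numbers stand for lower permeability and higher numbers for higher permeability), two compounds have been measured so far. Compound 1 `CN(C[C@H]1Cc2ncccc2CN1)[C@H]1CCCc2cccnc21` gives 460 nm/s, and compound 2 `NC(=O)NC/C=C\CN(C[C@H]1Cc2ncccc2CN1)[C@H]1CCCc2cccnc21` gives 5 nm/s, the lower of the two numbers. Going by the values given here, the only measured step, a 92-fold lower number from compound 1 to compound 2 (1.96 log units; beyond the scatter), is large and lies beyond the scatter. It involved a group taking the place of a hydrogen atom, on a saturated chain carbon bound to an amine nitrogen.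

Compound 3 `CCN(CC)CCCCN(C[C@H]1Cc2ncccc2CN1)[C@H]1CCCc2cccnc21` keeps the core of compound 2 and differs at that kind of place: a group of 8 heavy atoms (7 carbon, 1 nitrogen; no ring) in place of a group of 7 heavy atoms (4 carbon, 2 nitrogen, 1 oxygen; no ring), on a saturated chain carbon bound to an amine nitrogen. The entering group is 3-(diethylamino)propyl, while the leaving group has no common name. Among the compounds with values here, no measured step shows this exchange directly, so the one step available is only a loose guide. Compound 3 still carries a chain there, and a return to the level of compound 1, at 460 nm/s, is not expected. A modest rise is expected instead, far smaller than the earlier drop, though the evidence is thin. The estimated change is a 3.0-fold higher number from compound 2 to compound 3 (0.48 log units; beyond the scatter). Compound 3 is expected to read about 15 nm/s, with an estimated range from 2 nm/s to 100 nm/s.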

Compound 3, apparent permeability: 3 nm/s
Beside the measured number, compound 3's estimate is 5.0-fold (0.70 log units) above it; measured number inside the range.
By their numbers in this assay, from the lowest: compounds 3 and 2 (each within the scatter of the next); then compound 1.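

The exchange at this place brings a 1.7-fold lower number from compound 2 to compound 3 (0.22 log units; within the scatter) in this assay, so two quite different chains read alike here: 3-(diethylamino)propyl, with no hydrogen-bond donors, and the leaving group, which carries hydrogen-bond donors and a carbonyl. Compound 3 also gives a second comparison with the hydrogen of compound 1, namely a 150-fold lower number from compound 1 to compound 3 (2.19 log units; beyond the scatter) (large and beyond the scatter), so among these three compounds both chains on a saturated chain carbon bound to an amine nitrogen stand far from compound 1 and none goes against that pattern. No measurement offered here bears on why the two chains read alike or why both stand so far from compound 1.

The compounds shown leave open how short a chain at this place must be for the number to return toward that of compound 1, as an ethyl or a propyl group would test. They also leave open whether a chain ending in a hydroxyl or a carboxylic acid, or a longer chain ending in a diethylamino group, would read like compound 2 and compound 3 in this assay or apart from them.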